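The source may report more compounds than this note shows. Statements on the series, on what has been measured and on what is new or still open speak of the compounds shown alone.

Measured to date:
compound 1 `O=C(Nc1cccc(CNc2nccnc2Cl)c1)Nc1cccc2ccccc12`: > 40000 nM, a limit of the assay rather than a number
compound 2 `O=C(Nc1cccc(CNc2nccnc2Cl)c1)Nc1ccccc1F`: 7450 nM
compound 3 `CC(C)(C)c1ccc(NC(=O)Nc2cccc(CNc3nccnc3Cl)c2)cc1`: 6010 nM

In a functional assay on T-24 cells (Homo sapiens) for antiproliferative activity, read by MTT assay, with a stated time of 48 h (on this read-out higher numbers stand for weaker inhibition and lower numbers for stronger inhibition), compound 2 gives 7450 nM, which is the higher of the two numbers recorded. Compound 3 gives 6010 nM in this assay, and this lies within the scatter of compound 2, so the two cannot be ordered. For compound 1 this assay reports only (the limit of > 40000 nM in this assay, at which 1 of the 3 values shown sits), a limit and not a number, so it stands apart from the other two without a measured distance to either.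

Compound 4 `O=C(Nc1cccc(CNc2nccnc2Cl)c1)Nc1ccc(Cl)cc1Cl` has not yet been measured in this assay. Against compound 2 the change is 2,4-dichlorophenyl in place of 2-fluorophenyl on an amide-type nitrogen. For the measured compounds named here, no pair of measured compounds differs in one place, so there is no measured step to set the size of this change against, and the three values give no direction for a substituent change on that nitrogen.

The expected step from compound 2 to compound 4, a 1.5-fold lower number from compound 2 to compound 4 (0.17 log units; within the scatter), is therefore taken as small, not clearly beyond the scatter in either direction. Compound 4 is estimated at 5000 nM in this assay, with a range from 1500 nM to 20000 nM.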

Compound 4, half-maximal inhibitory concentration: 5740 nM
For compound 4 the middle estimate is 1.1-fold (0.06 log units) below the measured one; the measured number falls inside the stated range.
By their numbers in this assay, from the lowest: compounds 4, 3 and 2 (each within the scatter of the next). At a limit, above all of these: compound 1.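

In this assay, for the compounds shown here, the exchange of 2-fluorophenyl for 2,4-dichlorophenyl on the amide-type nitrogen gives a 1.3-fold lower number from compound 2 to compound 4 (0.11 log units; within the scatter), and this is the only step so far that can be read between two measured compounds. It sets a first measured size for a change at this position: going from the single fluorine of the 2-fluorophenyl group to the two chlorines of the 2,4-dichlorophenyl group, with the aromatic ring of carbon kept and no net charge on either group, produces no change that can be told from the scatter, so compound 2 and compound 4 cannot be ordered. No measured property at hand bears on this step.

As far as these compounds go, what an aminomethyl group or a carboxylic acid on the phenyl ring would do at this nitrogen remains open, as does a longer alkyl chain in place of that ring. The shared core is the same in all the compounds shown, so the effect of replacing its chlorine with an amine also stays open.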